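Acid dissociation notes on a two-compound quinoline-free series? No—core unnamed series

A few compounds are considered here, and "the series" means these few. Any claim that something is new, unique, unknown or untested is made for them only; others in the source may bear on it.

Measured so far:
compound 1, `COc1ccc(F)cc1CNCCCNc1ccnc2cc(Cc3ccc(C#N)cc3)ccc12`: 9.47
compound 2, `COc1cccc(CNCCCNc2ccnc3cc(Oc4cccc(N(C)C)c4)ccc23)c1O`: 9.28

In a physicochemical assay for acid dissociation, compound 1 gives 9.47, the higher of the two numbers recorded. Compound 2 gives 9.28 in this assay, and the gap between the two compounds lies within the scatter, so neither can be ranked above the other.

Compound 3, `COc1ccc(F)cc1CNCCCNc1ccnc2cc(Oc3ccc(C(C)(C)C)cc3)ccc12`, has not yet been measured. Relative to compound 1 the change is 4-(tert-butyl)phenoxy in place of 4-cyanobenzyl on an aromatic carbon. Within the data shown here, compound 1 and compound 2 differ in several places, yet their values sit within the scatter of each other, which is the only guide available for a change of this kind.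

The step of a number 0.07 log units lower from compound 1 to compound 3 (within the scatter) is expected to be none beyond the scatter, with no clear direction. Compound 3 is estimated at 9.4, with a range from 9 to 9.8.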

Compound 3, acid dissociation constant: 9.28
Estimate against measurement, compound 3: 0.12 log units above; measured number inside the range.
By their numbers in this assay, from the lowest: compounds 2, 3 and 1 (each within the scatter of the next).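

In this assay, among these compounds, 4-(tert-butyl)phenoxy in place of 4-cyanobenzyl on an aromatic carbon of the shared core gives a number 0.19 log units lower from compound 1 to compound 3 (within the scatter), the first single-place comparison. At this position, with the rest of compound 1 held fixed, a group with a nitrile and a carbon link gives way to one with a tert-butyl and an oxygen link, and the two values stay within the scatter of each other. Nothing available bears on the reason for this result.

As far as these compounds go, whether a different kind of group at this position, such as an amine or a carboxylic acid, would give a step beyond the scatter in this assay remains open. The compounds shown also leave open which site in the structure gives up the proton.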